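The source may report more compounds than this note shows. Statements on the series, on what has been measured and on what is new or still open speak of the compounds shown alone.

Compound 3 `O=C(Nc1ccc(Oc2ccnc3[nH]ccc23)c(F)c1)c1cc(-c2ccccc2)ccn1` reaches only the limit of a functional assay on MCF7 cells (Homo sapiens) for cytotoxicity, read by MTT assay, with a stated time of 72 h (a higher number here means a weaker inhibitor, a lower number a stronger inhibitor), where it gives > 10000 nM. Its parent compound 2 `O=C(Nc1ccc(Oc2ccnc3[nH]ccc23)cc1)c1cc(-c2ccccc2)ccn1` gives 3750 nM in this assay, and the fluoro substitution is an at least 2.6-fold higher number from compound 2 to compound 3 (0.42 log units; beyond the scatter). Going by the values given here, compound 1 `Cc1ccc(-c2ccc(C(=O)Nc3ccc(Oc4ccnc5[nH]ccc45)cc3)nc2)cc1` also sits at the limit, giving > 10000 nM in this assay; no single-change step links it to compound 2, so only their two values stand. Compound 4 `Cc1ccc(-c2ccnc(C(=O)Nc3ccc(Oc4ccnc5[nH]ccc45)c(F)c3)c2)cc1` differs from compound 3 by methyl in place of hydrogen on an aromatic carbon. Among the compounds with values here, no measured step isolates this change, and since the limit of > 10000 nM in this assay, at which 2 of the 3 values shown sit, already holds compound 3, no movement beyond the scatter is expected, so the step from compound 3 to compound 4 is estimated as a step that the limit leaves unreadable from compound 3 to compound 4. Compound 4 is therefore expected to give about 15000 nM in this assay, between 5000 nM and 50000 nM, most likely again only as a limit.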

Compound 4, half-maximal inhibitory concentration: 8430 nM
For compound 4 the middle estimate is 1.8-fold (0.25 log units) above the measured one; low and high end bracket the measured number.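

Compound 4 shows that a compound carrying the fluoro can give a number rather than a limit in this assay. Going from phenyl to 4-methylphenyl is an at least 1.1-fold lower number from compound 3 to compound 4 (0.07 log units; that floor lies within the scatter), so no change beyond the scatter is established, and its true size stays unknown: the limit of > 10000 nM in this assay, at which 2 of the 4 values shown sit.

On these data alone, what the methyl does without the fluoro, on compound 2, stays open. So does the outcome with an amine or a methoxy group in the same place on the aromatic ring.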